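Pyridin-2-yl to 4-methylpyrimidin-2-yl on a sulfonamide nitrogen

This account rests on a few compounds, and the source may have more. Where it says the series, first, only, none or still open, it means among the compounds named here.

Three compounds have been measured in a functional assay on MDA-MB-231 cells (Homo sapiens) for antiproliferative activity, read by sulforhodamine B assay, with a stated time of 48 h; a lower number here means a stronger inhibitor, a higher number a weaker inhibitor:

compound 1 `CC(=O)NS(=O)(=O)c1ccc(N/C(S)=N\c2ccnc3cc(C(F)(F)F)ccc23)cc1` gives 58600 nM
compound 2 `Cc1cc(NS(=O)(=O)c2ccc(N/C(S)=N\c3ccnc4cc(C(F)(F)F)ccc34)cc2)on1` gives 80300 nM
compound 3 `O=S(=O)(Nc1ccccn1)c1ccc(N/C(S)=N\c2ccnc3cc(C(F)(F)F)ccc23)cc1` gives 49300 nM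

For the measured compounds named here, compound 3 carries the lowest number of the three, yet a 1.2-fold lower number from compound 1 to compound 3 (0.08 log units; within the scatter) and a 1.6-fold lower number from compound 2 to compound 3 (0.21 log units; within the scatter) both lie within the scatter, so no compound can be called stronger or weaker than another. Compound 4 `Cc1ccnc(NS(=O)(=O)c2ccc(N/C(S)=N\c3ccnc4cc(C(F)(F)F)ccc34)cc2)n1` is the next variation: 4-methylpyrimidin-2-yl in place of pyridin-2-yl on a sulfonamide nitrogen. Going by the values given here, every measured step so far has exchanged the group on that same sulfonamide nitrogen, and each stayed within the scatter, including a 1.4-fold higher number from compound 1 to compound 2 (0.14 log units; within the scatter). On that basis compound 4 is expected to show no step beyond the scatter, a 1.1-fold higher number from compound 3 to compound 4 (0.05 log units; within the scatter). The estimate for compound 4 is therefore 55000 nM, with a range from 25000 nM to 120000 nM.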

Compound 4, half-maximal inhibitory concentration: 29800 nM
Compound 4: middle estimate off by 1.8-fold (0.27 log units), on the high side, and the stated range covers the measured number.
By their numbers in this assay, from the lowest: compounds 4, 3, 1 and 2 (each within the scatter of the next, the first and the last beyond it).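

In this assay, this position gives its first step beyond the scatter, a 2.7-fold lower number from compound 2 to compound 4 (0.43 log units; beyond the scatter), though the size is modest. The other two steps, a 1.7-fold lower number from compound 3 to compound 4 (0.22 log units; within the scatter) and a 2.0-fold lower number from compound 1 to compound 4 (0.29 log units; within the scatter), stay within the scatter, so compound 4 cannot be separated from compound 3 or compound 1. No supporting measurement explains these numbers.

Still open, from the compounds shown here alone, is how an unsubstituted pyrimidin-2-yl would compare on this sulfonamide nitrogen, which would help separate the methyl from the ring. Going by these compounds, a plain phenyl or a bare hydrogen there is equally open.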